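Shared-core series: cytotoxicity step from compound 2 to compound 4

This account rests on a few compounds, and the source may have more. Where it says the series, first, only, none or still open, it means among the compounds named here.

Compound 2 `O=C(OC[C@H]1CN(c2ccc(-n3cc(-c4ccccn4)cn3)c(F)c2)C(=O)O1)c1ccccc1` stands at the ceiling of an ADME assay on HEK293-A cells (Homo sapiens) for cytotoxicity, read by MTT assay, with a stated time of 48 h; a higher number here means a weaker inhibitor, a lower number a stronger inhibitor: its reading of > 400 ug/mL is a limit, not a number. Compound 1 `CN(CCC#N)C[C@H]1CN(c2ccc(-n3cc(-c4ccccn4)cn3)c(F)c2)C(=O)O1` likewise returns only a limit, > 400 ug/mL, in this assay. Compound 3 `CS(=O)(=O)NC[C@H]1CN(c2ccc(-n3cc(-c4ccccn4)cn3)c(F)c2)C(=O)O1` gives 314 ug/mL in this assay, so two of three values sit at the limit of > 400 ug/mL in this assay, at which 2 of the 3 values shown sit. Among the measured steps, a step that the two limits leave unreadable from compound 1 to compound 2, while an at least 1.2-fold lower number from compound 2 to compound 3 (0.10 log units; that floor lies within the scatter) and an at least 1.2-fold lower number from compound 1 to compound 3 (0.10 log units; that floor lies within the scatter). Compound 4 `NC(=O)[C@H]1CN(c2ccc(-n3cc(-c4ccccn4)cn3)c(F)c2)C(=O)O1` carries the change (carbamoyl in place of (benzoyloxy)methyl on a saturated ring carbon). For the measured compounds named here, no measured step touches a carbamoyl group, and the one readable step from compound 2 lies within the scatter, so no movement beyond the scatter is expected in this assay, and a further limit is likely. Compound 4 is estimated at 400 ug/mL (range 250 ug/mL to 640 ug/mL), an expected step of a number no higher from compound 2 to compound 4 (the limit leaves the size open).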

Compound 4, half-maximal inhibitory concentration: 152 ug/mL
For compound 4 the middle estimate is 2.6-fold (0.42 log units) above the measured one; measured number below the stated range.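

Carbamoyl on this saturated ring carbon is the first change in this assay to read beyond the scatter (in place of (benzoyloxy)methyl, an at least 2.6-fold lower number from compound 2 to compound 4 (0.42 log units; beyond the scatter)). The direction is the same against the other two groups (in place of ((2-cyanoethyl)(methyl)amino)methyl, an at least 2.6-fold lower number from compound 1 to compound 4 (0.42 log units; beyond the scatter) and in place of (methanesulfonamido)methyl, a 2.1-fold lower number from compound 3 to compound 4 (0.32 log units; beyond the scatter)). Among those three earlier groups, all of which keep a saturated chain carbon on the ring, no step read beyond the scatter.

On these data alone, whether the step belongs to the carbamoyl group itself or to the loss of that chain carbon stays open. A carboxylic acid, an amine or a longer chain ending in carbamoyl at this place would separate the two.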